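Diaryl ureas with pyridyl groups: moving the ring nitrogen

The source may report more compounds than this note shows. Statements on the series, on what has been measured and on what is new or still open speak of the compounds shown alone.

Three diaryl ureas have been run so far. In a functional assay on the whole organism with Mus musculus as the target, in the maximal electroshock model, with a stated time of 30 min (a higher number here means that more compound is needed for the effect, a lower number that less compound is needed), compound 1 `O=C(Nc1ccncc1)Nc1c(Cl)cccc1Cl` gives 100 mg/kg and compound 2 `Cc1cc(C)c(NC(=O)Nc2ccncc2)c(Cl)c1` gives 100 mg/kg. Compound 3 `Cc1cccc(Cl)c1NC(=O)Nc1ccccn1` gives 100 mg/kg in this assay, so it sits level with compounds 1 and 2 at the digits recorded, with no separation beyond the scatter of the method. Compound 4 `Cc1cccc(Cl)c1NC(=O)Nc1cccnc1` has not yet been measured in this assay. It differs from compound 3 by pyridin-3-yl in place of pyridin-2-yl on an amide-type nitrogen. Within the data shown here, no step between measured compounds is available, and the three values recorded give no hint of movement in either direction, so the step of no change at the digits printed from compound 3 to compound 4 (within the scatter) is expected to be none beyond the scatter. Compound 4 is accordingly expected to give about 100 mg/kg in this assay, within a range of 50 mg/kg to 200 mg/kg.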

Compound 4, minimum effective dose: 100 mg/kg
The estimate for compound 4 equals the measured number at the digits printed, within the range that was stated.
By their numbers in this assay, from the lowest: compounds 1, 2, 3 and 4 (each within the scatter of the next).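

In this assay, pyridin-3-yl in place of pyridin-2-yl on the amide-type nitrogen gives no change at the digits printed from compound 3 to compound 4 (within the scatter). Among these compounds, this is the first comparison that differs in one place, and it shows that, on this core, the two pyridyl isomers cannot be told apart in this read-out. Nothing available accounts for this result.

Going by these compounds, it remains open whether a phenyl or piperidin-1-yl group at this place would read differently. On these data alone, it is also open whether a carboxylic acid on the pyridine ring would separate from compound 3.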